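This account rests on a few compounds, and the source may have more. Where it says the series, first, only, none or still open, it means among the compounds named here.

Three related compounds share one core, each carrying an imidazole ring on the saturated part of the core and a nitrogen-linked substituent on the aromatic part. Compound 1 `CS(=O)(=O)Nc1ccc(O)c2c1CCCC2c1c[nH]cn1` bears a methanesulfonamido group together with a hydroxy group. Compound 2 `CS(=O)(=O)Nc1cccc2c1CCCCC2c1c[nH]cn1` keeps the methanesulfonamido group but has no hydroxy group and a saturated ring one carbon larger. Compound 3 `CC(=O)Nc1cccc2c1CCCC2c1c[nH]cn1` carries an acetamido group instead of the methanesulfonamido group. In a functional assay on Urethra with Alpha-1A adrenergic receptor (Oryctolagus cuniculus) as the target (a higher number here means a larger maximal response, a lower number a smaller maximal response), compound 1 gives 34%. Compound 2 reaches 17%, and compound 3 reaches 70%. Compound 1 therefore stands second highest of the three: compound 2 lies below it, and compound 3 lies well above it, both gaps beyond the usual scatter of this assay.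

Compound 4 `CS(=O)(=O)Nc1ccc(F)c2c1CCCC2c1c[nH]cn1` is the next compound to be tested. It differs from compound 1 in one place: fluoro in place of hydroxy on an aromatic carbon. Among the measured compounds shown here, no two of the measured compounds differ by this change alone, so there is no direct step to lean on. The hydroxy group is a hydrogen-bond donor and acceptor, and the fluoro group is neither. Without a comparable step, the estimated step of a number 6 percentage points lower from compound 1 to compound 4 (within the scatter) is expected to stay small, likely within the scatter, with a slight lean toward a lower response. Compound 4 is expected to give about 28%, with a plausible range from 8% to 55%.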

Compound 4, largest response reached (reported as efficacy), in percent of the reference or control that the assay uses: 64%
Beside the measured number, compound 4's estimate is 36 percentage points below it; the whole stated range lies below it.
By their numbers in this assay, from the lowest: compound 2; then compound 1; then compounds 4 and 3 (each within the scatter of the next).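

In this assay, putting fluoro in place of hydroxy on the aromatic carbon para to a methanesulfonamido group gives a step of a number 30 percentage points higher from compound 1 to compound 4 (beyond the scatter) and shows that this one position can change the maximal response on its own. Among the compounds shown here, none of the earlier compounds differed by this change alone, so this is the first direct reading of what the position does, and the step runs against the small change that might have been assumed for a swap of a single heavy atom. The numbers show the size and direction of the step, but no measurement shown here explains why the response rises with this exchange.

All of this rests on a single pair, so it holds only for hydroxy and fluoro at this place, on the shared core with a methanesulfonamido group. On these data alone, it remains open whether a chloro or methoxy group at the same carbon would give a response closer to that of compound 1 or of compound 4, and whether the same exchange would give a similar step with an acetamido group on the core.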